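The compounds below may be only part of what the source reports. "The series", "measured", "known", "first", "only" and "open" are said of these compounds alone.

Measured so far in an assay on HeLa cells for binding affinity to 5-hydroxytryptamine receptor 6 (Homo sapiens); a higher number here means a weaker inhibitor, a lower number a stronger inhibitor:
- compound 1 `COc1ccc(NS(=O)(=O)c2ccc3c(Cl)cccc3c2)cc1N1CCN(C)CC1`: 0.794 nM
- compound 2 `COc1ccc(NS(=O)(=O)c2cccc(C#N)c2)cc1N1CCN(C)CC1`: 63.1 nM
- compound 3 `COc1ccc(NS(=O)(=O)c2c(C)sc3ccc(Cl)cc23)cc1N1CCN(C)CC1`: 1.26 nM

Compound 2 has the highest number of the three. Its nearest neighbour is compound 3, which lies far below it, beyond the scatter; compound 1 lies further below still, also beyond the scatter. Both of those carry a larger bicyclic group on the sulfonamide, whereas compound 2 carries a single ring.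

Compound 4 `COc1ccc(NS(=O)(=O)c2ccccc2)cc1N1CCN(C)CC1` differs from compound 2 by hydrogen in place of cyano on an aromatic carbon. Within the data shown here, no measured pair shows this change, so the step must be estimated from compound 2 alone. Because compound 2 already gives 63.1 nM, only a small step is expected in this assay, likely toward a higher number but possibly within the scatter: a 1.6-fold higher number from compound 2 to compound 4 (0.20 log units; within the scatter). Compound 4 is therefore expected at 100 nM, with a range of 30 nM to 400 nM.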

Compound 4, inhibition constant: 10 nM
For compound 4 the middle estimate is 10-fold (1.00 log units) above the measured one, and the stated range ends above it.
By their numbers in this assay, from the lowest: compounds 1 and 3 (each within the scatter of the next); then compound 4; then compound 2.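

In this assay, among these compounds, the change from 3-cyanophenyl to phenyl gives a 6.3-fold lower number from compound 2 to compound 4 (0.80 log units; beyond the scatter) and is the first step here that can be read at a single place. It shows that the cyano group on this aromatic carbon is not needed for a low number, since the unsubstituted ring gives the lower one. Nothing shown bears on why the step runs this way. On these data alone, whether a methoxy group, a chlorine or an amine at this place would go lower or higher than hydrogen remains open. So does whether a cyano group elsewhere on the ring would give the same step.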